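The source may hold more compounds than are shown below. What is called first, only, known or untested is meant among the compounds shown, and "the series" means these compounds.

Compound 1 `COc1cc(OC)c(C(=O)/C=C/c2ccccc2OC)c(OC)c1`: 8100 nM
Compound 2 `COc1cc(OC)c(C(=O)/C=C/c2ccccc2SC)c(OC)c1`: 7600 nM
Compound 3 `COc1cccc(/C=C/C(=O)c2c(OC)cc(OC)cc2OC)c1`: 3100 nM

In a functional assay on PC-3 cells (Homo sapiens) for cytotoxicity, with a stated time of 48 h (a higher number here means a weaker inhibitor, a lower number a stronger inhibitor), compound 3 holds the lowest number of these three, beyond the scatter from both others. Compound 4 `COc1cc(OC)c(C(=O)/C=C/c2ccccc2)c(OC)c1` has hydrogen in place of methoxy on an aromatic carbon. Among the measured compounds shown here, no measured step removes that methoxy outright. The closest steps replace the 3-methoxyphenyl group itself: a 2.6-fold lower number from compound 1 to compound 3 (0.42 log units; beyond the scatter) and a 2.5-fold lower number from compound 2 to compound 3 (0.39 log units; beyond the scatter), both modest, whereas a 1.1-fold lower number from compound 1 to compound 2 (0.03 log units; within the scatter) stays within the scatter. On that evidence, a step no larger than those two is expected in this assay, towards a higher number, and it may not clear the scatter. The expected step is a 1.8-fold higher number from compound 3 to compound 4 (0.25 log units; within the scatter). Compound 4 is estimated at 5500 nM, with an expected range from 2500 nM to 11000 nM.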

Compound 4, half-maximal inhibitory concentration: 5100 nM
Beside the measured number, compound 4's estimate is 1.1-fold (0.03 log units) above it; the measured number falls inside the stated range.
By their numbers in this assay, from the lowest: compounds 3, 4, 2 and 1 (each within the scatter of the next, the first and the last beyond it).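

In this assay, removing the methoxy gives a 1.6-fold higher number from compound 3 to compound 4 (0.22 log units; within the scatter) and the other two comparisons give a 1.5-fold lower number from compound 2 to compound 4 (0.17 log units; within the scatter) and a 1.6-fold lower number from compound 1 to compound 4 (0.20 log units; within the scatter) so the unsubstituted phenyl of compound 4 lies within the scatter of all three earlier compounds. The gap between compound 1 and compound 3 therefore cannot be read as a clear gain or loss relative to plain phenyl. Nothing available explains these results. From the compounds shown here alone, whether an amine or a carboxylic acid on this aromatic ring would move the number beyond the scatter remains open.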